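The source may hold more compounds than are shown below. What is called first, only, known or untested is meant among the compounds shown, and "the series" means these compounds.

In a functional assay on HeLa cells (Homo sapiens) for antiproliferative activity, read by CCK-8 assay, with a stated time of 72 h, tested at 8 uM (on this read-out lower numbers stand for a weaker effect and higher numbers for a stronger effect at the one concentration tested), compound 1 `Nc1ccccc1NC(=O)c1ccc(CSC(=S)N2CCN(c3ccccc3)CC2)cc1` gives 73.1% and compound 2 `COc1ccc(N2CCN(C(=S)SCc3ccc(C(=O)Nc4ccccc4N)cc3)CC2)cc1` gives 52.3%, the lower of the two numbers shown so far. Among the compounds with values here, the only measured step, a number 20.8 percentage points lower from compound 1 to compound 2 (beyond the scatter), corresponds to methoxy in place of hydrogen on an aromatic carbon and lowered the number beyond the scatter. Compound 3 `Nc1ccccc1NC(=O)c1ccc(CSC(=S)N2CCN(c3ccc(F)cc3)CC2)cc1` differs from compound 2 by fluoro in place of methoxy on an aromatic carbon. Within the data shown here, no measured step carries fluoro in place of methoxy, so the step from compound 1 to compound 2 is the only one that bears on it: the methoxy that came with the lower number now leaves, and fluoro, a single heavy atom, enters in its place. A move back toward the number of compound 1 is therefore expected, though fluoro is not hydrogen and the recovery may be partial. Compound 3 is expected to give about 64%, between 50% and 78%, an expected step of a number 11.7 percentage points higher from compound 2 to compound 3 (beyond the scatter).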

Compound 3, a percentage reported as inhibition, at one concentration (the size of the read-out at that concentration, not a potency): 64.5%
The estimate for compound 3 lay 0.5 percentage points below the measured number; measured number inside the range.
By their numbers in this assay, from the lowest: compound 2; then compounds 3 and 1 (each within the scatter of the next).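

At this position, on an aromatic carbon para to a large group, the lower number does not come with every replacement of hydrogen: in this assay there is a number 12.2 percentage points higher from compound 2 to compound 3 (beyond the scatter) when fluoro takes the place of methoxy. Against hydrogen, fluoro gives a number 8.6 percentage points lower from compound 1 to compound 3 (within the scatter), so of the two groups shown here only methoxy separates from hydrogen beyond the scatter. Nothing measured here accounts for the difference between methoxy and fluoro.

Open, going by these compounds, is whether chloro, hydroxy or an amine at the same position would stay with hydrogen and fluoro or fall with methoxy, and whether a longer chain such as ethoxy would go further than methoxy. With one concentration per compound, these numbers show a stronger or weaker effect at that concentration only and leave open how the compounds would compare at any other concentration.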